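This account rests on a few compounds, and the source may have more. Where it says the series, first, only, none or still open, it means among the compounds named here.

Going by the values given here, in a functional assay on A549 cells (Homo sapiens) for cytotoxicity, read by resazurin assay, with a stated time of 72 h (on this read-out lower numbers stand for stronger inhibition and higher numbers for weaker inhibition), compound 1 (`O=C(/C=C/c1ccc(OCCCCO[N+](=O)[O-])c(O)c1)OCCCCO[N+](=O)[O-]`) gives 410 nM and stands lowest of the two numbers measured so far. Compound 2 (`COc1cc(/C=C/C(=O)OCc2ccc(OCc3c(-c4ccccc4)no[n+]3[O-])cc2)ccc1O`) gives 17200 nM on the same read-out, a gap well beyond the usual scatter. Compound 3 (`COc1cc(/C=C/C(=O)OCCCCO[N+](=O)[O-])ccc1OCCCCO[N+](=O)[O-]`) differs from compound 1 in one place: methyl in place of hydrogen on an oxygen on an aromatic ring with methyl in place of hydrogen on an oxygen on an aromatic ring, so hydroxy becomes methoxy. Among the compounds with values here, no measured pair shows this change alone, so only a tentative expectation is possible: a modest weakening in this assay that lies slightly beyond the scatter. The expected step is a 2.4-fold higher number from compound 1 to compound 3 (0.39 log units; beyond the scatter) in this estimate. Compound 3 is estimated at 1000 nM within a range of 300 nM to 4000 nM for now.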

Compound 3, half-maximal inhibitory concentration: > 50000 nM
Compound 3 ended at the assay's limit; the forecaster's own chance of this, stated with the estimate: 3%; middle value at least 50-fold (1.69 log units) from the limit.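

In this assay, going by these compounds alone, the hydroxy on this aromatic ring gives the first direct reading of this position: changing it to methoxy, a single added methyl on the oxygen, gives an at least 120-fold higher number from compound 1 to compound 3 (2.08 log units; beyond the scatter). So this one small change can cost nearly all of the activity seen for compound 1 here. Compound 3 gives > 50000 nM, which is a limit of the assay and not a number, so the step has only a floor: the limit of > 50000 nM in this assay, at which 1 of the 3 values shown sits.

From the compounds shown here alone, whether any group other than hydrogen can sit on this oxygen remains open, and an ethyl or acetyl group there would test that. Why methyl has so large an effect cannot be read from these compounds.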